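Amide variations on the shared core of compound 1

This account rests on a few compounds, and the source may have more. Where it says the series, first, only, none or still open, it means among the compounds named here.

Measured compounds:
compound 1 `COc1ccc(C(=O)NC[C@H]2c3[nH]c4ccccc4c3C[C@H]3[C@H]4c5[nH]c6ccccc6c5C[C@@H]([C@H](C#N)N23)N4C)cc1`: in a functional assay on BGC-823 cells (Homo sapiens) for cytotoxicity, read by MTT assay, with a stated time of 72 h (a higher number here means a weaker inhibitor, a lower number a stronger inhibitor), compound 1 gives 320 nM
compound 2 `CCc1ccc(C(=O)NC[C@H]2c3[nH]c4ccccc4c3C[C@H]3[C@H]4c5[nH]c6ccccc6c5C[C@@H]([C@H](C#N)N23)N4C)cc1`: compound 2 gives 660 nM
compound 3 `CN1[C@@H]2c3[nH]c4ccccc4c3C[C@H]1[C@H](C#N)N1[C@@H](CNC(=O)c3cc4ccccc4s3)c3[nH]c4ccccc4c3C[C@@H]21`: compound 3 gives 240 nM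

Compound 1 holds the second highest of the three numbers. Its nearest neighbour is compound 3, reached by a 1.3-fold lower number from compound 1 to compound 3 (0.12 log units; within the scatter), a gap that falls within the scatter of repeated measurements. The furthest is compound 2, reached by a 2.1-fold higher number from compound 1 to compound 2 (0.31 log units; beyond the scatter). The third measured step, a 2.8-fold lower number from compound 2 to compound 3 (0.44 log units; beyond the scatter), is likewise modest.

Compound 4 `COc1ccc(/C=C/C(=O)NC[C@H]2c3[nH]c4ccccc4c3C[C@H]3[C@H]4c5[nH]c6ccccc6c5C[C@@H]([C@H](C#N)N23)N4C)cc1` is not yet measured. It differs from compound 1 only at the amide: 2-(4-methoxyphenyl)ethenyl in place of 4-methoxyphenyl on a carbonyl carbon. Cut one bond further out, the change reads (4-methoxyphenyl)carbonyl to (2-(4-methoxyphenyl)ethenyl)carbonyl.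

All three measured steps also alter the group on the carbonyl carbon next to the amide-type nitrogen, and none of them exceeds a modest size. Going by the values given here, no measured step inserts a double bond outside aromatic rings, so the direction of the present change is not settled by the data. The step of no change at the digits printed from compound 1 to compound 4 (within the scatter) is therefore expected to stay within, or only slightly beyond, the scatter. Compound 4 is estimated at 320 nM, with a range from 130 nM to 800 nM.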

Compound 4, half-maximal inhibitory concentration: 5450 nM
The estimate for compound 4 lay 17-fold (1.23 log units) below the measured number; the whole stated range lies below it.
By their numbers in this assay, from the lowest: compounds 3 and 1 (each within the scatter of the next); then compound 2; then compound 4.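

Working notes on the group on the carbonyl carbon: in this assay, this position proved far less tolerant than the earlier aryl exchanges suggested, since 2-(4-methoxyphenyl)ethenyl in place of 4-methoxyphenyl gives a 17-fold higher number from compound 1 to compound 4 (1.23 log units; beyond the scatter), a large step with the 4-methoxyphenyl ring itself retained. The same replacement raises the number against the other two amides, with a 23-fold higher number from compound 3 to compound 4 (1.36 log units; beyond the scatter) from the 1-benzothiophen-2-yl group and an 8.3-fold higher number from compound 2 to compound 4 (0.92 log units; beyond the scatter) from the 4-ethylphenyl group, so all three steps point the same way among the compounds shown. No measurement offered here accounts for this loss.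

The compounds shown leave open whether the loss follows the double bond outside the aromatic rings or the greater length of the group, a question that 2-(4-methoxyphenyl)ethyl on the carbonyl carbon would address directly. Also open, as far as these compounds go, is whether the ethenyl unit carries the same penalty with other rings at its end, such as 4-ethylphenyl or 1-benzothiophen-2-yl.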